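Swapping Dimethoxyphenyl for Methylthiophene in a Level Series

The source may hold more compounds than are shown below. What is called first, only, known or untested is meant among the compounds shown, and "the series" means these compounds.

In a functional assay on HepG2 cells (Homo sapiens) for cytotoxicity, read by MTT assay, with a stated time of 48 h (a higher number here means a weaker inhibitor, a lower number a stronger inhibitor), compound 1 `Cc1ccc(/C=C2/S/C(=N/c3ccccc3)N(Cc3ccncc3)C2=O)cc1` gives 19700 nM, compound 2 `O=C1/C(=C\c2ccc(Cl)cc2)S/C(=N/c2ccccc2)N1Cc1ccncc1` gives 28800 nM and compound 3 `COc1ccc(/C=C2/S/C(=N/c3ccccc3)N(Cc3ccncc3)C2=O)cc1OC` gives 28900 nM. Compound 3 therefore stands within the scatter of both other compounds. Compound 4 `Cc1ccc(/C=C2/S/C(=N/c3ccccc3)N(Cc3ccncc3)C2=O)s1` has not yet been measured. It carries 5-methylthiophen-2-yl in place of 3,4-dimethoxyphenyl on a double-bonded chain carbon bound to a double-bonded ring carbon. Two measured steps exchange the group at this same place: a 1.5-fold higher number from compound 1 to compound 3 (0.17 log units; within the scatter) and a 1.0-fold higher number from compound 2 to compound 3 (0.00 log units; within the scatter). A third, a 1.5-fold higher number from compound 1 to compound 2 (0.16 log units; within the scatter), exchanges only chloro for methyl on an aromatic carbon. From the compounds shown here alone, all three lie within the scatter, but none brings in a five-membered aromatic ring, so the new group itself remains untested. On this evidence, no step beyond the scatter is expected in this assay. The expected change is a 1.2-fold lower number from compound 3 to compound 4 (0.06 log units; within the scatter). For compound 4, the estimated value is 25000 nM, with an expected range from 12000 nM to 50000 nM.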

Compound 4, half-maximal inhibitory concentration: 23100 nM
For compound 4 the middle estimate is 1.1-fold (0.03 log units) above the measured one; the range from low to high includes it.
By their numbers in this assay, from the lowest: compounds 1, 4, 2 and 3 (each within the scatter of the next).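

In (this assay), the place on a double-bonded chain carbon bound to a double-bonded ring carbon now also holds a five-membered aromatic ring with a hetero atom, and every step to it stays within the scatter (a 1.3-fold lower number from compound 3 to compound 4 (0.10 log units; within the scatter); a 1.2-fold lower number from compound 2 to compound 4 (0.10 log units; within the scatter); a 1.2-fold higher number from compound 1 to compound 4 (0.07 log units; within the scatter)). Among the compounds shown, the change from a six-membered aromatic ring of carbon only to 5-methylthiophen-2-yl therefore sets compound 4 apart from none of compound 1, compound 2 or compound 3. No measurement given here bears on why the series stays level.

From the compounds shown here alone, whether an amine or a carboxylic acid at this place would bring a step beyond the scatter remains open. So does the part played by the methyl group, as thiophen-2-yl without it is not among the compounds shown.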